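Anilino series on the shared core: compound 4

The source may report more compounds than this note shows. Statements on the series, on what has been measured and on what is new or still open speak of the compounds shown alone.

Measured so far:
compound 1 `Cc1ccc(NC2=CC(=O)c3nc4n(c3C2=O)[C@H]2OC[C@@H](O)[C@H]2OC4)cc1C` — 860 nM
compound 2 `CCc1ccc(NC2=CC(=O)c3nc4n(c3C2=O)[C@H]2OC[C@@H](O)[C@H]2OC4)cc1` — 1290 nM
compound 3 `CCOc1ccccc1NC1=CC(=O)c2nc3n(c2C1=O)[C@H]1OC[C@@H](O)[C@H]1OC3` — 2450 nM

In a functional assay on MGC-803 cells (Homo sapiens) for inhibition, read by sulforhodamine B assay (on this read-out lower numbers stand for stronger inhibition and higher numbers for weaker inhibition), compound 3 gives the highest of the three numbers; its gap to compound 2 is within the scatter, while a 2.8-fold higher number from compound 1 to compound 3 (0.45 log units; beyond the scatter) lies beyond it. Compound 4 `O=C1C=C(Nc2cccc(F)c2)C(=O)c2c1nc1n2[C@H]2OC[C@@H](O)[C@H]2OC1` is derived from compound 3 by the change (3-fluorophenyl in place of 2-ethoxyphenyl on an amine nitrogen). Within the data shown here, two measured steps bear on it, both arriving at the 2-ethoxyphenyl: a 2.8-fold higher number from compound 1 to compound 3 (0.45 log units; beyond the scatter) and a 1.9-fold higher number from compound 2 to compound 3 (0.28 log units; within the scatter). Both run to higher numbers, one of them beyond the scatter, so leaving the 2-ethoxyphenyl for another aryl group on the amine nitrogen may be expected to move the number back down. Among the measured compounds shown here, no measured step involves a fluorine or any halogen, so the size of the return is uncertain. For compound 4 the expected step is a 1.6-fold lower number from compound 3 to compound 4 (0.21 log units; within the scatter), a modest lowering in this assay. Compound 4 is estimated at 1500 nM in this assay, with a range from 600 nM to 4000 nM.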

Compound 4, half-maximal inhibitory concentration: 2180 nM
Estimate against measurement, compound 4: 1.5-fold (0.16 log units) below; the range from low to high includes it.
By their numbers in this assay, from the lowest: compounds 1, 2, 4 and 3 (each within the scatter of the next, the first and the last beyond it).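

In this assay a halogen on the aryl group at the amine nitrogen gives no clear separation from 2-ethoxyphenyl (a 1.1-fold lower number from compound 3 to compound 4 (0.05 log units; within the scatter)). 3-Fluorophenyl also stays within the scatter of 4-ethylphenyl (a 1.7-fold higher number from compound 2 to compound 4 (0.23 log units; within the scatter)), while 3,4-dimethylphenyl remains apart from it (a 2.5-fold higher number from compound 1 to compound 4 (0.40 log units; beyond the scatter)), so compound 1 now stands beyond the scatter from both compound 3 and compound 4, which carry quite different aryl groups. Nothing available explains these gaps among the aryl groups.

Still open, as far as these compounds go, is whether 3-chlorophenyl, 3-aminophenyl or 3-carboxyphenyl at this nitrogen would stay within the same narrow band of values. Also open, from the compounds shown here alone, is whether a phenyl group bearing a longer chain, such as 4-butylphenyl, would separate from compound 1.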